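The source may hold more compounds than are shown below. What is called first, only, known or untested is meant among the compounds shown, and "the series" means these compounds.

Measured compounds, with their results in an assay on microsomes from brain for inhibition of Fatty-acid amide hydrolase 1 (Rattus norvegicus), read by fluorescence and HPLC, with a stated time of 60 min; on this read-out higher numbers stand for weaker inhibition and lower numbers for stronger inhibition:
compound 1, `CCCCCCCCc1ccc(OC(C)C(=O)Cn2nnc(-c3ccccc3)n2)cc1`, gives 24 nM
compound 2, `CC(Oc1ccc(Oc2ccc(F)cc2)cc1)C(=O)Cn1nnc(-c2ccccc2)n1`, gives 24 nM
compound 3, `CC(Oc1ccc(-c2ccccc2)cc1)C(=O)Cn1nnc(-c2ccccc2)n1`, gives 15 nM

Compound 2 stands level with compound 1 at the digits given, the two together the highest numbers of the three; the step of a 1.6-fold lower number from compound 2 to compound 3 (0.20 log units; within the scatter) stays within the scatter, as does no change at the digits printed from compound 1 to compound 2 (within the scatter).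

Compound 4 is `COC(=O)c1ccc(-c2nnn(CC(=O)C(C)Oc3ccc(Oc4ccc(F)cc4)cc3)n2)cc1`. It differs from compound 2 by methoxycarbonyl in place of hydrogen on an aromatic carbon, which reads one bond further out as phenyl to 4-(methoxycarbonyl)phenyl. Within the data shown here, no measured step alters this phenyl; all three measured steps change the other aryl group of the shared core and all lie within the scatter. With nothing in the data pointing either way, the step of a 1.0-fold higher number from compound 2 to compound 4 (0.02 log units; within the scatter) is expected to stay within the scatter. Compound 4 is therefore estimated at 25 nM, in the range 8 nM to 80 nM.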

Compound 4, half-maximal inhibitory concentration: 36 nM
Estimate against measurement, compound 4: 1.4-fold (0.16 log units) below; measured number inside the range.
By their numbers in this assay, from the lowest: compounds 3, 1, 2 and 4 (each within the scatter of the next, the first and the last beyond it).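

In this assay, among these compounds, the step of a 1.5-fold higher number from compound 2 to compound 4 (0.18 log units; within the scatter) is the first measured change to the phenyl of the shared core, and it stays within the scatter. At this place on the ring, para to a large group, methoxycarbonyl thus brings in 4 heavy atoms and 2 hydrogen-bond acceptors without a step beyond the scatter. Nothing given here explains this result.

The compounds shown leave open whether a carboxylic acid or an amine at this place would also stay within the scatter. They also leave open whether methoxycarbonyl would read the same alongside the octyl of compound 1 or the phenyl of compound 3.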